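The source may hold more compounds than are shown below. What is called first, only, known or untested is meant among the compounds shown, and "the series" means these compounds.

Compound 1 `COC(=O)C1=C(C)NC(=O)NC1c1ccoc1` gives 2% in an assay on membranes from HeLa cells for displacement of a labelled ligand from adenosine receptor A3 (Homo sapiens), read by scintillation counting, with a stated time of 180 min, tested at 1 uM; on this read-out higher numbers stand for more inhibition at the one concentration tested (going by the name of the read-out) and lower numbers for less inhibition. Compound 2 `CCCOC(=O)C1=C(C)NC(=O)NC1c1ccoc1` gives 11% in this assay. Compound 3 `COC(=O)C1=C(C)N(C)C(=O)NC1c1ccco1` gives 9% in this assay.

Compounds 1 and 2 share a core and differ in one place: ethyl in place of hydrogen on a saturated chain carbon bound to an oxygen next to a carbonyl group. That change brought a number 9 percentage points higher from compound 1 to compound 2 (within the scatter), so the two values are not separated by this assay. Compound 3 has a different core; the difference between the cores of compound 1 and compound 3 is not broken down here. In this assay compound 3 sits with compound 2 and with compound 1 inside the usual scatter, so nothing among the three measured compounds is distinguished.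

Compound 4 `CCCOC(=O)C1=C(C)N(C)C(=O)NC1c1ccco1` has not been measured in this assay. It differs from compound 3 by ethyl in place of hydrogen on a saturated chain carbon bound to an oxygen next to a carbonyl group, the same change, at the same place, as the one that leads from compound 1 to compound 2; among the compounds shown this change occurs in two pairs. Going by the values given here, since the only guide is that earlier pair, compound 4 is expected to move from compound 3 by a number 6 percentage points higher from compound 3 to compound 4 (within the scatter), a step expected to be small because a number 9 percentage points higher from compound 1 to compound 2 (within the scatter) was small and within the scatter. Compound 4 is therefore estimated at 15% in this assay, with a likely range from 4% to 28%; a small number is expected, not a limit.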

Compound 4, a percentage reported as inhibition, at one concentration (the size of the read-out at that concentration, not a potency): 8%
For compound 4 the middle estimate is 7 percentage points above the measured one; low and high end bracket the measured number.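

On the core of compound 3, replacing methoxycarbonyl with propoxycarbonyl brought a number 1 percentage points lower from compound 3 to compound 4 (within the scatter) in this assay. Set beside the same change on the core of compound 1, the two steps cannot be told apart: the same change on two cores in this assay, a number 9 percentage points higher (within the scatter) from compound 1 to compound 2 and a number 1 percentage points lower (within the scatter) from compound 3 to compound 4, 10 percentage points apart, within the scatter of two such steps Carried from one core to the other, the change therefore gave no result that this assay can separate from the first, and on neither core did it produce a step beyond the scatter; this does not show that the two cores respond alike, only that any difference between them is not visible here, where all four values are low and a single concentration was read.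

The compounds shown leave open whether another group at this place on the saturated chain carbon, such as a longer chain, an amine or a carboxylic acid, would give a step beyond the scatter on either core. They also leave open what the difference between the core of compound 1 and the core of compound 3 contributes on its own, as no pair shown isolates it.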